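Moving the Fluorine Around the Phenoxy Ring

A few compounds are considered here, and "the series" means these few. Any claim that something is new, unique, unknown or untested is made for them only; others in the source may bear on it.

Compound 1, `C=CC(=O)NCc1coc(-c2c(N)ncnc2Nc2ccc(Oc3ccccc3)c(Cl)c2)n1`, gives 0.8 h in an in vitro ADME assay on microsomes from liver (Mus musculus) for metabolic stability, tested at 5 uM; a higher number here means that the compound lasts longer, a lower number that the compound disappears faster.
Compound 2, `C=CC(=O)NCc1coc(-c2c(N)ncnc2Nc2ccc(Oc3cc(Cl)ccc3Cl)c(Cl)c2)n1`, gives 0.95 h in this assay.
Compound 3, `C=CC(=O)NCc1coc(-c2c(N)ncnc2Nc2ccc(Oc3cccc(F)c3)c(Cl)c2)n1`, reaches only a limit in this assay, > 1.66 h; this is a limit and not a number.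

Compound 3 therefore stands at the limit (the limit of > 1.66 h in this assay, at which 1 of the 3 values shown sits), the only one of the three to do so. The step from compound 1 to compound 3 is an at least 2.0-fold higher number from compound 1 to compound 3 (0.31 log units; beyond the scatter), and the step from compound 2 to compound 3 is an at least 1.7-fold higher number from compound 2 to compound 3 (0.24 log units; that floor lies within the scatter). The step from compound 1 to compound 2 is a 1.2-fold higher number from compound 1 to compound 2 (0.07 log units; within the scatter).

Compound 4, `C=CC(=O)NCc1coc(-c2c(N)ncnc2Nc2ccc(Oc3ccc(F)cc3)c(Cl)c2)n1`, has not yet been measured. It differs from compound 3 only in where the fluorine sits: 4-fluorophenyl in place of 3-fluorophenyl on an oxygen on an aromatic ring. Among the compounds with values here, no measured pair moves the fluorine from one position to another on that ring, so the closest guide is the step from compound 1 to compound 3, where placing a fluorine on that ring lifted the half-life to the limit. A change of position alone is expected to do little, so compound 4 is expected to stay close to compound 3, with the step that the limit leaves unreadable from compound 3 to compound 4 expected. The half-life of compound 4 in this assay is estimated at 1.7 h, within a range from 0.9 h to 3.4 h.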

Compound 4, half-life: > 1.66 h
Compound 4 ended at the assay's limit; the forecaster's own chance of this, stated with the estimate: 50%; the middle value lies beyond the limit too.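

Compound 4 shows that the gain in this assay is not confined to 3-fluorophenyl, since 4-fluorophenyl on the same oxygen also takes the compound to the assay's limit. Against the plain phenyl, the fluorine gives an at least 2.0-fold higher number from compound 1 to compound 4 (0.31 log units; beyond the scatter), and against 2,5-dichlorophenyl the change gives an at least 1.7-fold higher number from compound 2 to compound 4 (0.24 log units; that floor lies within the scatter), so only the first of these steps clearly clears the usual scatter. The step between the two fluorine placements cannot be read, as compound 3 and compound 4 both carry a limit rather than a number, and the series now has two compounds stopped at the same point: the limit of > 1.66 h in this assay, at which 2 of the 4 values shown sit.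

From the compounds shown here alone, what stays open is whether either fluorine placement outlasts the other, and how far beyond the limit either compound would go. The compounds shown also do not tell whether a single chlorine, a methoxy group or a nitrile on that ring would match the fluorine in this assay.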